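Stability of a Bicyclic Acid Series in Buffer

The compounds below may be only part of what the source reports. "The series", "measured", "known", "first", "only" and "open" are said of these compounds alone.

Measured compounds:
Compound 1 `CC(C)(C)C1=C(C(=O)O)N2C(=O)[C@H]([C@H](O)c3ccccc3)[C@H]2O1`: 7 h
Compound 2 `CC(C)(C)C1=C(C(=O)O)N2C(=O)[C@H]([C@H](O)c3ccccc3)[C@@H]2O1`: 0.5 h
Compound 3 `CC(C)(C)C1=C(C(=O)O)N2C(=O)[C@H]([C@@H](O)c3ccccc3)[C@H]2O1`: 8.9 h

In an ADME assay, in phosphate buffer, at 28 degrees C, at pH 7.0 (on this read-out lower numbers stand for a shorter-lived compound and higher numbers for a longer-lived compound), compound 3 stands highest of the three numbers; compound 1 lies within the scatter of it, while compound 2 lies far lower, as an 18-fold higher number from compound 2 to compound 3 (1.25 log units; beyond the scatter) shows. The steps measured so far are changes of configuration only (the fact that compounds 1 and 2 differ only in the configuration as drawn, (the fact that compounds 1 and 3 differ only in the configuration as drawn), (the fact that compounds 2 and 3 differ only in the configuration as drawn)); two were large and one was within the scatter. Compound 4 `CC(C)(C)C1=C(C(=O)O)N2C(=O)[C@H]([C@@H](O)CCc3ccncc3)[C@H]2O1` differs from compound 3 by 2-(pyridin-4-yl)ethyl in place of phenyl on a saturated chain carbon bound to an oxygen on a saturated carbon and a saturated ring carbon. For the measured compounds named here, no measured step alters the atoms and bonds, so none bears directly on this change, and no step beyond the scatter is expected in this assay. Compound 4 is therefore estimated at 7 h, with a range of 2 h to 20 h, corresponding to an expected step of a 1.3-fold lower number from compound 3 to compound 4 (0.10 log units; within the scatter).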

Compound 4, half-life: 15.8 h
Estimate against measurement, compound 4: 2.3-fold (0.35 log units) below; measured number inside the range.
By their numbers in this assay, from the lowest: compound 2; then compounds 1, 3 and 4 (each within the scatter of the next, the first and the last beyond it).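

In this assay there is a 1.8-fold higher number from compound 3 to compound 4 (0.25 log units; within the scatter) when 2-(pyridin-4-yl)ethyl enters in place of phenyl on a saturated chain carbon. For the compounds shown here, this is the first measured change of atoms and bonds, and it shows that this position, in the configuration of compound 3, accepts a longer chain with a ring nitrogen without a step beyond the scatter. The earlier comparisons shown here of configuration do not bear on this replacement.

Chain and ring nitrogen changed together here, and a 2-phenylethyl group would separate them. Going by these compounds, whether the same replacement holds in the configuration of compound 2 remains open.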